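Adding Chloro to the Core: One Small Step

The source may report more compounds than this note shows. Statements on the series, on what has been measured and on what is new or still open speak of the compounds shown alone.

Measured in an ADME assay on RAW264.7 cells (Mus musculus) for cytotoxicity, read by MTT assay, with a stated time of 72 h, tested at 100 uM; a higher number here means a stronger effect of the compound at the concentration tested, a lower number a weaker effect:
compound 1 `O=C(Cn1c(=O)oc2ccccc21)Nc1cc(C(F)(F)F)ccc1Cl` gives 15.4%
compound 2 `O=C(Cn1c(=O)oc2cc(Cl)ccc21)Nc1cc(C(F)(F)F)ccc1Cl` gives 12.1%
compound 3 `O=C(Cn1c(=O)oc2ccccc21)Nc1ccccn1` gives 28.4%

The change from compound 1 to compound 2 is chloro in place of hydrogen on an aromatic carbon. It made a number 3.3 percentage points lower from compound 1 to compound 2 (within the scatter). Compound 3 carries a different amide partner than compound 1; the difference between the two cores is not broken down here. Among the three, compound 3 stands highest, and both gaps to it lie beyond the scatter.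

Compound 4 `O=C(Cn1c(=O)oc2cc(Cl)ccc21)Nc1ccccn1` has not been measured. Within the data shown here, it differs from compound 3 by chloro in place of hydrogen on an aromatic carbon, the same change as the one from compound 1 to compound 2. In this assay the expected step is a number 3.4 percentage points lower from compound 3 to compound 4 (within the scatter), because a number 3.3 percentage points lower from compound 1 to compound 2 (within the scatter) for the same change was small. The estimate for compound 4 is therefore 25%, expected to fall between 13% and 37%.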

Compound 4, a percentage reported as inhibition, at one concentration (the size of the read-out at that concentration, not a potency): 43.7%
Compound 4: the middle estimate sits 18.7 percentage points below what was measured; the measured number lies above the stated range.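

In this assay chloro in place of hydrogen gave a number 15.3 percentage points higher from compound 3 to compound 4 (beyond the scatter) on this amide partner, and the small step seen with the other partner did not carry over. The same change did not keep its size from one partner to the other: the same change on two cores in this assay, a number 3.3 percentage points lower (within the scatter) from compound 1 to compound 2 and a number 15.3 percentage points higher (beyond the scatter) from compound 3 to compound 4, 18.6 percentage points apart, beyond the scatter of two such steps. This shows that, for these two pairs, the step depends on what else the molecule carries; it does not show why, or how the change would behave on any other partner.

Still open, on these data alone, is whether bromo or an amine on the same aromatic carbon would also give steps that differ between the two partners. A third amide partner, such as a simple phenyl ring, could show which of the two steps is more typical.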